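Aryl in place of alkyl on the aromatic nitrogen

A few compounds are considered here, and "the series" means these few. Any claim that something is new, unique, unknown or untested is made for them only; others in the source may bear on it.

Compound 1 `Cc1[nH]n(C)c(=O)c1/N=N/c1c(O)cc(S(=O)(=O)O)c2ccccc12` in an assay on BaF3 cells with thrombopoietin receptor (Homo sapiens) as the target, read by a luciferase reporter (on this read-out higher numbers stand for larger maximal responses and lower numbers for smaller maximal responses), gives < 5%, which is a limit of the assay. Compound 2 `Cc1[nH]n(C(C)(C)C)c(=O)c1/N=N/c1c(O)cc(S(=O)(=O)O)c2ccccc12` in this assay gives < 5%, also a limit. The step that the two limits leave unreadable from compound 1 to compound 2 stays unreadable because both values sit at the limit of < 5% in this assay, at which 2 of the 2 values shown sit. Compound 3 `Cc1[nH]n(-c2cccc(C(F)(F)F)c2)c(=O)c1/N=N/c1c(O)cc(S(=O)(=O)O)c2ccccc12` differs from compound 2 by 3-(trifluoromethyl)phenyl in place of tert-butyl on an aromatic nitrogen. For the measured compounds named here, no measured step bears on a change of this kind, so no direction can be drawn from the series itself. Compound 3 is therefore estimated at 15% in this assay, with a range of 0% to 60%. The expected step of a number at least 10 percentage points higher from compound 2 to compound 3 (that floor lies within the scatter) is likewise uncertain.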

Compound 3, largest response reached (reported as efficacy), in percent of the reference or control that the assay uses: 62%
The estimate for compound 3 lay 47 percentage points below the measured number; measured number above the stated range.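

In this assay, 3-(trifluoromethyl)phenyl on the aromatic nitrogen in place of tert-butyl gives a number at least 57 percentage points higher from compound 2 to compound 3 (beyond the scatter), and in place of methyl it gives a number at least 57 percentage points higher from compound 1 to compound 3 (beyond the scatter). This position therefore tolerates a change that yields a readable maximal response, and an aryl group reaches it where neither alkyl group does. The step between compound 1 and compound 2 cannot be read, as both rest at a limit: the limit of < 5% in this assay, at which 2 of the 3 values shown sit.

The compounds shown leave open whether the ring alone or the trifluoromethyl on it carries the step. A plain phenyl, or a phenyl bearing chlorine or a carboxylic acid, is not among them.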